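The source may hold more compounds than are shown below. What is called first, only, known or untested is meant among the compounds shown, and "the series" means these compounds.

Compound 3 `CCCCCCCCS(=O)(=O)Nc1cc(/C=C/c2ccc(OC)cc2)ccc1C(=O)O` gives the highest number of the three measured compounds in an assay on mitochondria (strain BALB/c) for inhibition of glycerol-3-phosphate acyltransferase 1, mitochondrial (Mus musculus), read by scintillation counting, with a stated time of 10 min (on this read-out higher numbers stand for weaker inhibition and lower numbers for stronger inhibition), at 38700 nM. Compound 1 `CCCCCCCCS(=O)(=O)Nc1cc(-c2ccc(Cl)cc2)ccc1C(=O)O` gives 18100 nM in this assay, and compound 2 `CCCCCCCCS(=O)(=O)Nc1cc(-c2ccccc2OC)ccc1C(=O)O` gives 16100 nM. Compound 4 `CCCCCCCCS(=O)(=O)Nc1cc(CCc2ccccc2)ccc1C(=O)O` differs from compound 3 by phenethyl in place of 2-(4-methoxyphenyl)ethenyl on an aromatic carbon. The measured steps that bear on this position are a 2.1-fold higher number from compound 1 to compound 3 (0.33 log units; beyond the scatter) and a 2.4-fold higher number from compound 2 to compound 3 (0.38 log units; beyond the scatter), both modest rises. Within the data shown here, no measured step removes the double bond or the methoxy group, so the direction of the change from compound 3 to compound 4 is open. The expected step is therefore a 1.2-fold lower number from compound 3 to compound 4 (0.08 log units; within the scatter), within the scatter. Compound 4 is accordingly estimated to give 32000 nM in this assay, within a range from 13000 nM to 80000 nM.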

Compound 4, half-maximal inhibitory concentration: 37500 nM
The estimate for compound 4 lay 1.2-fold (0.07 log units) below the measured number; the measured number falls inside the stated range.
By their numbers in this assay, from the lowest: compounds 2 and 1 (each within the scatter of the next); then compounds 4 and 3 (each within the scatter of the next).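

Phenethyl in place of 2-(4-methoxyphenyl)ethenyl gives a 1.0-fold lower number from compound 3 to compound 4 (0.01 log units; within the scatter), so this position tolerates the loss of both the double bond and the methoxy group taken together. Phenethyl also shows a 2.3-fold higher number from compound 2 to compound 4 (0.37 log units; beyond the scatter) and a 2.1-fold higher number from compound 1 to compound 4 (0.32 log units; beyond the scatter), modest rises that match those already seen with 2-(4-methoxyphenyl)ethenyl.

As far as these compounds go, what the double bond and the methoxy group each contribute alone remains open, as does the effect of an amine on the phenethyl ring. Nothing available explains these steps.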